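This account rests on a few compounds, and the source may have more. Where it says the series, first, only, none or still open, it means among the compounds named here.

Compound 1 `C=C(Br)C(=O)Nc1ccc(/C=C/C(=O)c2ccccc2)cc1` and compound 2 `C=C(Br)C(=O)Nc1ccc(/C=C/C(=O)c2cccc(OC)c2)cc1` share a core in which the amide-bearing ring carries the alkene and the carbonyl sits on the far ring. In an ADME assay on CCRF-CEM cells (Homo sapiens) for antiproliferative activity, with a stated time of 48 h (on this read-out higher numbers stand for weaker inhibition and lower numbers for stronger inhibition), compound 1 gives 4000 nM and compound 2 gives 2300 nM; the change between them is methoxy in place of hydrogen on an aromatic carbon and produces a 1.7-fold lower number from compound 1 to compound 2 (0.24 log units; within the scatter). Compound 3 `C=C(Br)C(=O)Nc1ccc(C(=O)/C=C/c2ccccc2OC)cc1` has the carbonyl and alkene arranged differently; how its core differs from that of compound 1 is not broken down here. In this assay compound 3 gives 580 nM, the lowest of the three numbers and beyond the scatter from both compound 2 and compound 1. Compound 4 `C=C(Br)C(=O)Nc1ccc(C(=O)/C=C/c2cccc(OC)c2OC)cc1` has not yet been measured. Among the measured compounds shown here, it differs from compound 3 by methoxy in place of hydrogen on an aromatic carbon, which is the same kind of change as the one from compound 1 to compound 2, though here the entering group stands ortho to a methoxy group already present. Resting on that earlier step, the step expected from compound 3 to compound 4 in this assay is a 1.5-fold lower number from compound 3 to compound 4 (0.16 log units; within the scatter). Compound 4 is therefore estimated at 400 nM, between 180 nM and 1200 nM.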

Compound 4, half-maximal inhibitory concentration: 710 nM
Compound 4: the middle estimate sits 1.8-fold (0.25 log units) below what was measured; low and high end bracket the measured number.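

In this assay, methoxy in place of hydrogen on an aromatic carbon gives a 1.2-fold higher number from compound 3 to compound 4 (0.09 log units; within the scatter). Set beside the earlier step, the two readings do not separate between the two cores: the same change on two cores in this assay, a 1.7-fold lower number (0.24 log units; within the scatter) from compound 1 to compound 2 and a 1.2-fold higher number (0.09 log units; within the scatter) from compound 3 to compound 4, 2.1-fold (0.33 log units) apart, within the scatter of two such steps. This gives no sign that the change behaves differently on the core of compound 3 than on the core of compound 1, but it does not show that the change carries over with a fixed size, as both steps lie within the scatter, and a modest real difference between the cores could remain hidden there.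

The compounds shown leave open whether any group entering at this place, ortho to a methoxy group, would move the number beyond the scatter, for instance a hydroxyl group, an amine, a chlorine atom or a longer ether such as ethoxy. They also leave open whether methoxy itself would give a larger step at another place on this ring.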